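A few compounds are considered here, and "the series" means these few. Any claim that something is new, unique, unknown or untested is made for them only; others in the source may bear on it.

In an assay on CHO cells for displacement of a labelled ligand from adenosine receptor A1 (Homo sapiens) (a lower number here means a stronger inhibitor, a higher number a weaker inhibitor), compound 1 `CCCn1c(=O)c2nc(-c3cnn(Cc4cc(C(F)(F)F)ccc4Cl)c3)[nH]c2n(CCC)c1=O` gives 1200 nM, the higher of the two numbers shown, while compound 2 `CC(C)Cn1c(=O)c2nc(-c3cnn(Cc4cccc(F)c4)c3)[nH]c2n(CC(C)C)c1=O` gives 830 nM; the gap between them lies within the scatter, so neither can be called the stronger inhibitor. Compound 3 `CCCn1c(=O)c2nc(-c3cnn(Cc4ccccc4OC)c3)[nH]c2n(CCC)c1=O` keeps the core and chains of compound 1 and alters only the outer aromatic group: 2-methoxyphenyl in place of 2-chloro-5-(trifluoromethyl)phenyl on a saturated chain carbon bound to an aromatic nitrogen. For the measured compounds named here, no measured pair shows what such a swap does, so in this assay only a modest shift, in either direction, is expected. Compound 3 is estimated at 900 nM, between 300 nM and 3000 nM. The expected step is a 1.3-fold lower number from compound 1 to compound 3 (0.12 log units; within the scatter), not beyond the scatter.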

Compound 3, inhibition constant: 59 nM
Compound 3: the middle estimate sits 15-fold (1.18 log units) above what was measured, and the stated range ends above it.
By their numbers in this assay, from the lowest: compound 3; then compounds 2 and 1 (each within the scatter of the next).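

In this assay, swapping 2-chloro-5-(trifluoromethyl)phenyl for 2-methoxyphenyl gives a 20-fold lower number from compound 1 to compound 3 (1.31 log units; beyond the scatter) with the core and chains unchanged. The outer aromatic group on this saturated chain carbon can therefore move the number far beyond the scatter, which compound 1 and compound 2 could not show, since they differ in more than one place. No evidence here explains the step. From the compounds shown here alone, the swap removes the chlorine and the trifluoromethyl together and adds the methoxy group, so their separate contributions stay unknown. A plain phenyl group would help to separate them.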